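The compounds below may be only part of what the source reports. "The series", "measured", "known", "first", "only" and "open" are said of these compounds alone.

Compound 1 `O=C(Nc1ccccc1)C1CCc2ccccc2N1`, compound 2 `O=C(Nc1ccccc1O)C1CCc2ccccc2N1` and compound 3 `O=C(Nc1ccccc1C(F)(F)F)C1CCc2ccccc2N1` share one core and differ only on the aromatic ring of the anilide. In a functional assay on NCI-H23 cells (Homo sapiens) for cytotoxicity, read by sulforhodamine B assay, with a stated time of 72 h (a higher number here means a weaker inhibitor of growth, a lower number a stronger inhibitor of growth), compound 1 gives 97100 nM, compound 2 gives 2230 nM and compound 3 gives 56800 nM. Compound 2 has the lowest number of the three: the step of a 44-fold lower number from compound 1 to compound 2 (1.64 log units; beyond the scatter) is large, and the step of a 25-fold higher number from compound 2 to compound 3 (1.41 log units; beyond the scatter) is large as well, while the step of a 1.7-fold lower number from compound 1 to compound 3 (0.23 log units; within the scatter) stays within the scatter. Compound 4 `CCCCCCCCC(=O)N1c2ccccc2CCC1C(=O)Nc1ccccc1O` keeps the hydroxy anilide of compound 2 and differs from it by octylcarbonyl in place of hydrogen on a nitrogen on an aromatic ring in a ring. For the measured compounds named here, none of the three measured steps touches this nitrogen; all of them concern substituents on the anilide ring, so no measured step bears directly on the change from compound 2 to compound 4. The direction of the effect therefore cannot be read from the data, and only a cautious expectation can be given. Compound 4 is expected to show 6000 nM in this assay, within a wide range from 600 nM to 60000 nM. This estimate corresponds to an expected step of a 2.7-fold higher number from compound 2 to compound 4 (0.43 log units; beyond the scatter).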

Compound 4, concentration for 50% growth inhibition: 55800 nM
For compound 4 the middle estimate is 9.3-fold (0.97 log units) below the measured one; the range from low to high includes it.
By their numbers in this assay, from the lowest: compound 2; then compounds 4, 3 and 1 (each within the scatter of the next).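

The nitrogen of the shared core is untouched in compounds 1, 2 and 3, and compound 4 shows that this position matters in this assay: octylcarbonyl in place of hydrogen gives a 25-fold higher number from compound 2 to compound 4 (1.40 log units; beyond the scatter) in this series. Compound 4 retains the hydroxy anilide, so that group alone does not secure the low number of compound 2. The data at hand offer no explanation for this shift.

From the compounds shown here alone, what remains open is whether the change follows from the length of the octyl chain or from the carbonyl on the nitrogen, which a shorter acyl group such as acetyl, or a plain methyl on the same nitrogen, would help separate. Also open, going by these compounds, is whether octylcarbonyl would have the same effect on the unsubstituted anilide of compound 1.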